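The source may report more compounds than this note shows. Statements on the series, on what has been measured and on what is new or still open speak of the compounds shown alone.

Of the compounds shown here, two of one shared core have been measured, compound 1 `O=C(/C=C\Nc1ccc(O)cc1)c1cn(-c2ccccc2)nc1-c1ccc(F)cc1` and compound 2 `COc1cc(N/C=C\C(=O)c2cn(-c3ccccc3)nc2-c2ccc(Cl)cc2)cc(OC)c1OC`. In a functional assay on HT-29 cells (Homo sapiens) for antiproliferative activity, read by MTT assay, with a stated time of 48 h (a higher number here means a weaker inhibitor, a lower number a stronger inhibitor), compound 1 gives 1900 nM, while compound 2 gives 12700 nM, the higher of the two numbers, and the gap between them lies beyond the usual scatter of such measurements. Compound 3 `COc1ccc(-c2nn(-c3ccccc3)cc2C(=O)/C=C\Nc2cc(OC)c(OC)c(OC)c2)cc1` has not yet been measured. It differs from compound 2 in one place: methoxy in place of chloro on an aromatic carbon. Going by the values given here, no measured pair shows what this exchange does on the shared core, and the two measured compounds differ in more than this one place, so no direction can be read from them. The expected step from compound 2 to compound 3 in this assay is therefore a 1.3-fold lower number from compound 2 to compound 3 (0.10 log units; within the scatter), a change not beyond the scatter. On that basis compound 3 is estimated at 10000 nM, within a range from 3000 nM to 40000 nM.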

Compound 3, half-maximal inhibitory concentration: 14600 nM
Beside the measured number, compound 3's estimate is 1.5-fold (0.16 log units) below it, and the stated range covers the measured number.
By their numbers in this assay, from the lowest: compound 1; then compounds 2 and 3 (each within the scatter of the next).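

In this assay, methoxy in place of chloro on an aromatic carbon, para to a large group, gives a 1.1-fold higher number from compound 2 to compound 3 (0.06 log units; within the scatter) on the shared core. Going by these compounds alone, this is the first direct reading of the exchange, and it shows that 4-chlorophenyl and 4-methoxyphenyl cannot be told apart at this place when the rest of compound 2 is kept. No supporting measurement is available to explain this result.

The compounds shown leave open whether an amine or a carboxylic acid at the same place would also stay within the scatter of compound 2. They also leave open whether methoxy in place of chloro would give a similar step on a compound that otherwise matches compound 1, whose structure differs from compound 2 in more than one place.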